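Working notes on a thiourea series against barnyard grass

The source may report more compounds than this note shows. Statements on the series, on what has been measured and on what is new or still open speak of the compounds shown alone.

Compound 3 `CSc1cc(C)nc(NC(=S)NC(=O)c2c(-c3ccc(Cl)cc3Cl)noc2C)n1` gives 47.1% in a functional assay on the whole organism (strain L.) for inhibition, with Echinochloa crus-galli as the target, with a stated time of 72 h, tested at 100 mg/L; a lower number here means less inhibition of growth, a higher number more inhibition of growth at the concentration tested. It stands second highest of the three measured numbers; its nearest neighbour is compound 1 `Cc1cc(O)nc(NC(=S)NC(=O)c2c(-c3ccc(Cl)cc3Cl)noc2C)n1`, which gives 46.8%, a difference within the scatter, and its furthest is compound 2 `COc1cc(C)nc2n/c(=N/C(=O)c3c(-c4ccc(Cl)cc4Cl)noc3C)sn12`, which gives 80.5%, a gap beyond the scatter. Within the data shown here, the one measured step on the same ring is a number 0.3 percentage points higher from compound 1 to compound 3 (within the scatter), so exchanging one substituent of that ring for another left the number where it was. Compound 4 `COc1cc(OC)nc(NC(=S)NC(=O)c2c(-c3ccc(Cl)cc3Cl)noc2C)n1` differs from compound 3 by 4,6-dimethoxypyrimidin-2-yl in place of 4-methyl-6-(methylsulfanyl)pyrimidin-2-yl on an amide-type nitrogen. Among the measured compounds shown here, no measured step covers a methoxy group on this ring; compound 2 carries methoxy and methyl, but its core differs, and its value shows only that this arrangement reached a higher number. Because a number 0.3 percentage points higher from compound 1 to compound 3 (within the scatter) was flat, compound 4 is expected to sit near compound 3, with a step of a number 2.9 percentage points higher from compound 3 to compound 4 (within the scatter) that is not expected to exceed the scatter. The estimate for compound 4 is 50%, with a range from 30% to 75%.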

Compound 4, percent growth inhibition at one concentration: 60.9%
Compound 4: middle estimate off by 10.9 percentage points, on the low side; low and high end bracket the measured number.
By their numbers in this assay, from the lowest: compounds 1 and 3 (each within the scatter of the next); then compound 4; then compound 2.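

At the amide-type nitrogen whose other neighbour is the thiocarbonyl carbon, the choice of substituent does change the reading in this assay. 4,6-Dimethoxypyrimidin-2-yl gives a number 13.8 percentage points higher from compound 3 to compound 4 (beyond the scatter) in place of 4-methyl-6-(methylsulfanyl)pyrimidin-2-yl and a number 14.1 percentage points higher from compound 1 to compound 4 (beyond the scatter) in place of 4-hydroxy-6-methylpyrimidin-2-yl, so the flat step between the two earlier substituents did not hold for every exchange at this position. No available data give a reason for this rise.

On these data alone, both substituents that leave differ from the one that enters in two groups at once, so it remains open whether one methoxy group alone, paired with methyl, carries the rise on this core. Also open, as far as these compounds go, is how an amino group or a longer alkoxy chain such as ethoxy would read in this place.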